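The source may hold more compounds than are shown below. What is called first, only, known or untested is meant among the compounds shown, and "the series" means these compounds.

Measured in a functional assay on A-375 cells (Homo sapiens) for antiproliferative activity, read by MTT assay, with a stated time of 24 h; a lower number here means a stronger inhibitor, a higher number a weaker inhibitor:
- compound 1 `C=CCOc1ccc2c(=O)c(-c3cc(OC)c(OC)cc3OC)coc2c1`: 4750 nM
- compound 2 `COc1cc(OC)c(-c2coc3cc(OCc4ccc(Cl)cc4)ccc3c2=O)cc1OC`: 1020 nM

Compound 2, at 1020 nM, holds the lower of the two numbers in this assay. The next compound, compound 3 `COc1cc(OC)c(-c2coc3cc(OCc4ccc(C(F)(F)F)cc4)ccc3c2=O)cc1OC`, carries trifluoromethyl in place of chloro on an aromatic carbon, para to a large group, turning the 4-chlorobenzyl into a 4-(trifluoromethyl)benzyl: trifluoromethyl in place of chloro on an aromatic carbon.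

Among the compounds with values here, only one measured step is available, a 4.7-fold lower number from compound 1 to compound 2 (0.67 log units; beyond the scatter). It is modest, though beyond the scatter, and it exchanged vinyl for the whole 4-chlorophenyl. Within the data shown here, the data hold no step that changes a group on that aromatic ring, so this step bears on the question only indirectly. The smaller swap is therefore expected to leave this assay with no shift beyond the scatter, in neither direction. The expected step is a 1.1-fold higher number from compound 2 to compound 3 (0.05 log units; within the scatter). For compound 3 the estimated value is 1150 nM, with an expected range from 480 nM to 2800 nM.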

Compound 3, half-maximal inhibitory concentration: 2280 nM
Compound 3: the middle estimate sits 2.0-fold (0.30 log units) below what was measured, and the stated range covers the measured number.
By their numbers in this assay, from the lowest: compound 2; then compound 3; then compound 1.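

In this assay, the group on this aromatic carbon is not silent: chloro to trifluoromethyl gives a 2.2-fold higher number from compound 2 to compound 3 (0.35 log units; beyond the scatter), so a change confined to that ring moves the number beyond the scatter. The benzyl-type group still holds an advantage over the allyl-type chain of compound 1 after the swap, with a 2.1-fold lower number from compound 1 to compound 3 (0.32 log units; beyond the scatter), so that advantage does not depend on chloro alone, although its size changes with the ring group. Nothing available here explains why the number shifts with this exchange.

With only chloro and trifluoromethyl shown on this ring, it stays open whether an amine, a carboxylic acid or a plain hydrogen on the same aromatic carbon would lower or raise the number. The compounds also leave open how far either ring group can carry the number below that of compound 2, 1020 nM.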